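The source may hold more compounds than are shown below. What is called first, only, known or untested is meant among the compounds shown, and "the series" means these compounds.

In an assay on CHO cells for displacement of a labelled ligand from prostaglandin E2 receptor EP2 subtype (Mus musculus), read by scintillation counting (a higher number here means a weaker inhibitor, a lower number a stronger inhibitor), compound 1, `O=C(O)/C=C/c1ccc(Cc2ccccc2)cc1OCCc1ccc2ccccc2c1`, gives only a limit of the assay, > 10000 nM. Compound 2, `O=C(O)C#Cc1ccc(Cn2cccn2)cc1OCCc1ccc2ccccc2c1`, likewise gives only a limit in this assay, > 10000 nM. Going by the values given here, compound 2 thus stands at the limit of > 10000 nM in this assay, at which 2 of the 2 values shown sit, and no measured step leads away from it; no compound measured so far shows a number in this assay. Compound 3, `O=C(O)CCCc1ccc(Cn2cccn2)cc1OCCc1ccc2ccccc2c1`, differs from compound 2 in one place: 3-carboxypropyl in place of 2-carboxyethynyl on an aromatic carbon. The acid end of the chain is kept, while the triple bond of the chain in compound 2 is gone in compound 3. Both values shown are limits, and they do not reveal how such a change moves the inhibition constant. Compound 3 is therefore expected to remain near the same limit. The step estimated here, a step that the limit leaves unreadable from compound 2 to compound 3, means no movement beyond the scatter that could be read from the measurements. Compound 3 is expected to give about 20000 nM in this assay, within a range of 5000 nM to 100000 nM, and most probably the assay will again report only a limit for compound 3.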

Compound 3, inhibition constant: 1800 nM
Compound 3: the middle estimate sits 11-fold (1.05 log units) above what was measured; the whole stated range lies above it.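

Going by these compounds alone, compound 3 is the first compound here to give a readable number in this assay, which shows that the group on this aromatic carbon, para to a (1H-pyrazol-1-yl)methyl group, can shift the inhibition constant while the rest of the molecule stays the same. Going by these compounds, putting 3-carboxypropyl in place of 2-carboxyethynyl gives an at least 5.5-fold lower number from compound 2 to compound 3 (0.74 log units; beyond the scatter), and the true size of this step stays unknown, as compound 2 gives only a limit: the limit of > 10000 nM in this assay, at which 2 of the 3 values shown sit. The acid end is common to both chains, so this pair ties the gain to a chain that has lost its triple bond and has 6 heavy atoms rather than 5, but it cannot separate those two differences.

On these data alone, whether a shorter saturated chain such as 2-carboxyethyl would hold this gain, or a longer chain such as 4-carboxybutyl would extend it, remains open. Within the data shown here, also open are whether an amide could stand in for the carboxylic acid, and whether a benzyl group, seen only in compound 1 with a different chain, could replace the (1H-pyrazol-1-yl)methyl group alongside 3-carboxypropyl.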